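This account rests on a few compounds, and the source may have more. Where it says the series, first, only, none or still open, it means among the compounds named here.

Compound 1, `O=c1[nH]cnc2c1c(-c1ccoc1)cn2[C@@H]1O[C@H](CO)[C@@H](O)[C@H]1O`, and compound 2, `COc1ncnc2c1c(-c1ccoc1)cn2[C@@H]1O[C@H](CO)[C@@H](O)[C@H]1O`, share a core but differ in more than one place, and the difference between the two cores is not broken down here. In a functional assay on HL-60 cells (Homo sapiens) for antiproliferative activity, read by XTT assay, with a stated time of 72 h (a lower number here means a stronger inhibitor, a higher number a weaker inhibitor), compound 1 gives 6370 nM, while compound 2 gives 150 nM, the lowest of the two numbers recorded, with compound 1 the nearest neighbour. Compound 3, `O=c1[nH]cnc2c1c(-c1cccs1)cn2[C@@H]1O[C@H](CO)[C@@H](O)[C@H]1O`, carries thiophen-2-yl in place of furan-3-yl on an aromatic carbon relative to compound 1. In this assay compound 3 reaches only a limit of > 20000 nM and no number. That step, an at least 3.1-fold higher number from compound 1 to compound 3 (0.49 log units; beyond the scatter), is at least modest, and because one of the three values sits at the limit of > 20000 nM in this assay, at which 1 of the 3 values shown sits, its true size is open at the top.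

Compound 4, `COc1ncnc2c1c(-c1cccs1)cn2[C@@H]1O[C@H](CO)[C@@H](O)[C@H]1O`, has not yet been measured. Against compound 2 it shows (thiophen-2-yl in place of furan-3-yl on an aromatic carbon), the same change as between compound 1 and compound 3, placed on the same ring carbon. Starting from compound 2 at 150 nM, and given that compound 1 to compound 3 moved by an at least 3.1-fold higher number from compound 1 to compound 3 (0.49 log units; beyond the scatter), compound 4 is expected to lose potency, with an estimated step of a 4.7-fold higher number from compound 2 to compound 4 (0.67 log units; beyond the scatter). Going by the values given here, the estimate for compound 4 in this assay is therefore 700 nM, with a range from 200 nM to 4000 nM, the upper end kept wide since the only measured step is itself a limit.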

Compound 4, half-maximal inhibitory concentration: 80 nM
For compound 4 the middle estimate is 8.8-fold (0.94 log units) above the measured one, and the stated range ends above it.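

On the core of compound 2, putting thiophen-2-yl in place of furan-3-yl gives a 1.9-fold lower number from compound 2 to compound 4 (0.27 log units; within the scatter) in this assay, so compound 2 and compound 4 cannot be told apart in this assay. The change therefore does not carry over from the core of compound 1 to the core of compound 2, and the two steps differ: the same change on two cores in this assay, an at least 3.1-fold higher number (0.49 log units; beyond the scatter) from compound 1 to compound 3 and a 1.9-fold lower number (0.27 log units; within the scatter) from compound 2 to compound 4, at least 5.8-fold (0.76 log units) apart, beyond the scatter of two such steps This shows that, in this series, the step measured on one core is no safe guide to the step on the other, but it rests on a single pair per core, does not explain the difference, and leaves the size of the gap open at one end since compound 3 stands at a limit of the assay, not at a number: the limit of > 20000 nM in this assay, at which 1 of the 4 values shown sits.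

The compounds shown leave open whether the same split between the two cores would appear with other groups on this aromatic carbon, such as phenyl, furan-2-yl or thiophen-3-yl. They also leave open how the change would behave on further cores, for instance one that carries an amine or a methyl group where the core of compound 1 and the core of compound 2 differ.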